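This account rests on a few compounds, and the source may have more. Where it says the series, first, only, none or still open, it means among the compounds named here.

Measured compounds in a functional assay on HT-29 cells (Homo sapiens) for cytotoxicity, read by MTT assay; on this read-out lower numbers stand for stronger inhibition and higher numbers for weaker inhibition:

Compound 1, `CCCOc1ccc(O)c(C(=O)/C=C/c2ccc(C)s2)c1`, gives 126000 nM.
Compound 2, `CCCCOc1ccc(O)c(C(=O)/C=C/c2ccc(C)s2)c1`, gives 71400 nM.
Compound 3, `CCOc1ccc(OC)cc1C(=O)/C=C/c1ccc(C)s1`, gives 100 nM.

Compound 1 and compound 2 share one core and differ by methyl in place of hydrogen on a saturated chain carbon, three bonds along the chain from an oxygen on an aromatic ring; the step is a 1.8-fold lower number from compound 1 to compound 2 (0.25 log units; within the scatter). Compound 3 carries a core built from the same atoms as compound 1, joined differently; the difference between the two cores is not broken down here. Compound 3 stands far apart from the other two: its number in this assay lies well beyond the scatter from both compound 1 and compound 2.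

Compound 4, `CCCOc1ccc(OC)cc1C(=O)/C=C/c1ccc(C)s1`, is not yet measured. It differs from compound 3 by methyl in place of hydrogen on a saturated chain carbon, two bonds along the chain from an oxygen on an aromatic ring. This is the same kind of change as that between compound 1 and compound 2, not the same: there the methyl enters three bonds along the chain from the oxygen on the aromatic ring, here two bonds along the chain. Among the compounds with values here, the step from compound 3 to compound 4 in this assay is expected to be a 1.4-fold lower number from compound 3 to compound 4 (0.15 log units; within the scatter), because the one step of this kind on record, a 1.8-fold lower number from compound 1 to compound 2 (0.25 log units; within the scatter), lies within the scatter, and the step is expected to stay small on the other core as well. Compound 4 is thus estimated at 70 nM, with a range from 20 nM to 250 nM.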

Compound 4, half-maximal inhibitory concentration: 86600 nM
Estimate against measurement, compound 4: 1200-fold (3.09 log units) below, outside the stated range (above it).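

In this assay, the ethoxy to propoxy change gives an 870-fold higher number from compound 3 to compound 4 (2.94 log units; beyond the scatter), so a single added methyl is enough to separate these two compounds on this core. The small step on the core of compound 1 therefore does not carry over to the core of compound 3: the same change on two cores in this assay, a 1.8-fold lower number (0.25 log units; within the scatter) from compound 1 to compound 2 and an 870-fold higher number (2.94 log units; beyond the scatter) from compound 3 to compound 4, 1500-fold (3.18 log units) apart, beyond the scatter of two such steps. This does not show that the core alone sets the size of the step, since the methyl enters three bonds along the chain from the oxygen on the aromatic ring in one pair and two bonds along in the other, and each step rests on one pair of compounds.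

The compounds shown leave open how the core of compound 3 responds to a butoxy group, a longer chain or an isopropoxy group in place of the ethoxy. They also leave open whether an ethoxy group on the core of compound 1 would give a step of either kind.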